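A few compounds are considered here, and "the series" means these few. Any claim that something is new, unique, unknown or untested is made for them only; others in the source may bear on it.

In a functional assay on A549 cells (Homo sapiens) for inhibition, read by MTT assay, with a stated time of 72 h (on this read-out higher numbers stand for weaker inhibition and lower numbers for stronger inhibition), compound 3 `CC1=NN(c2ccccc2)C(=O)[C@]12C(=O)C=CC[C@H]2c1cccc(C)c1` gives 13100 nM and compound 1 `CC1=NN(c2ccccc2)C(=O)[C@]12C(=O)C=CC[C@H]2c1ccccc1[N+](=O)[O-]` gives 12900 nM, two values within the scatter of each other, while compound 2 `CC1=NN(c2ccccc2)C(=O)[C@]12C(=O)C=CC[C@H]2c1ccc(C)cc1` stands lower at 2890 nM. Compound 4 `COc1ccccc1[C@@H]1CC=CC(=O)[C@]12C(=O)N(c1ccccc1)N=C2C` departs from compound 3 by 2-methoxyphenyl in place of 3-methylphenyl on a saturated ring carbon, with 2-methoxyphenyl in place of 3-methylphenyl on a saturated ring carbon. Within the data shown here, two measured steps bear on this: a 1.0-fold higher number from compound 1 to compound 3 (0.01 log units; within the scatter), which lies within the scatter, and a 4.5-fold higher number from compound 2 to compound 3 (0.66 log units; beyond the scatter), a modest step involving 4-methylphenyl, a group compound 4 lacks. The 2-methoxyphenyl of compound 4 resembles the 2-nitrophenyl of compound 1 in its numbering, so no step beyond the scatter is expected in this assay. The estimated step is a 1.3-fold lower number from compound 3 to compound 4 (0.12 log units; within the scatter). For compound 4 the estimate is 10000 nM, with an expected range from 3500 nM to 28000 nM.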

Compound 4, half-maximal inhibitory concentration: 3960 nM
Compound 4: the middle estimate sits 2.5-fold (0.40 log units) above what was measured; the range from low to high includes it.
By their numbers in this assay, from the lowest: compounds 2 and 4 (each within the scatter of the next); then compounds 1 and 3 (each within the scatter of the next).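

At this ring carbon, the 2-position of the phenyl does not settle the value in this assay: methoxy in place of nitro on an aromatic carbon gives a 3.3-fold lower number from compound 1 to compound 4 (0.51 log units; beyond the scatter), beyond the scatter. The change from 3-methylphenyl to 2-methoxyphenyl gives a 3.3-fold lower number from compound 3 to compound 4 (0.52 log units; beyond the scatter), while the change from 4-methylphenyl to 2-methoxyphenyl gives only a 1.4-fold higher number from compound 2 to compound 4 (0.14 log units; within the scatter), within the scatter, so two different groups now share the lower level. No evidence is available to explain these differences. The compounds shown leave open how 2-methylphenyl or 4-methoxyphenyl would read here. They also leave open whether an amine on that aromatic carbon would stay at the lower level.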